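Tert-butyl in place of fluoro: second occurrence

A few compounds are considered here, and "the series" means these few. Any claim that something is new, unique, unknown or untested is made for them only; others in the source may bear on it.

Measured compounds, with their values in a functional assay for antagonist activity at transient receptor potential cation channel subfamily V member 1 (Homo sapiens), read by calcium flux; on this read-out higher numbers stand for weaker inhibition and lower numbers for stronger inhibition:
compound 1 `CN1CCC(NC(=O)Nc2cccc3[nH]ncc23)c2ccc(F)cc21` — compound 1 gives 34 nM
compound 2 `CN1CCC(NC(=O)Nc2cccc3[nH]ncc23)c2ccc(C(C)(C)C)cc21` — compound 2 gives 115 nM
compound 3 `O=C(Nc1cccc2[nH]ncc12)NC1CCN(Cc2ccccc2)c2ccc(F)cc21` — compound 3 gives 66 nM

Compound 2 differs from compound 1 by one change, (tert-butyl in place of fluoro on an aromatic carbon). This change produced a 3.4-fold higher number from compound 1 to compound 2 (0.53 log units; beyond the scatter). Compound 3 and compound 1 share no single counted difference; the difference between the two cores is not broken down here. Compound 3 stands near compound 2 and near compound 1, and in both cases the gap is within the scatter, so no order among the three is drawn.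

Compound 4 `CC(C)(C)c1ccc2c(c1)C(NC(=O)Nc1cccc3[nH]ncc13)CCN2Cc1ccccc1` has not yet been measured. It differs from compound 3 by tert-butyl in place of fluoro on an aromatic carbon. The place of this change is described in the same words as for the step from compound 1 to compound 2, so this is the same change made a second time, now on the core of compound 3.

For the measured compounds named here, only the one earlier occurrence is available, and it cannot be known whether the core of compound 3 carries it over unchanged. The working expectation is that compound 4 sits beyond compound 3 by about the same amount, namely a 3.3-fold higher number from compound 3 to compound 4 (0.52 log units; beyond the scatter), because the same change gave a 3.4-fold higher number from compound 1 to compound 2 (0.53 log units; beyond the scatter) in this assay. On that basis compound 4 is estimated at 220 nM in this assay, with a plausible range from 100 nM to 500 nM to allow for the core being different.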

Compound 4, half-maximal inhibitory concentration: 121 nM
Beside the measured number, compound 4's estimate is 1.8-fold (0.26 log units) above it; measured number inside the range.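

In this assay, tert-butyl in place of fluoro on the core of compound 3 gives a 1.8-fold higher number from compound 3 to compound 4 (0.26 log units; within the scatter) and so, taken alone on this core, the step draws no order between the two compounds. Set beside the first occurrence of the change, the two steps cannot be told apart: the same change on two cores in this assay, a 3.4-fold higher number (0.53 log units; beyond the scatter) from compound 1 to compound 2 and a 1.8-fold higher number (0.26 log units; within the scatter) from compound 3 to compound 4, 1.8-fold (0.27 log units) apart, within the scatter of two such steps. The pair is therefore compatible with a single step size carrying from one core to the other, but it does not establish this, since only two occurrences are available and the step lies beyond the scatter on one core and within it on the other; equally, it does not show that the core of compound 3 dampens the change.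

The compounds shown leave open how other groups on the same aromatic carbon, such as chloro, methoxy, trifluoromethyl, nitrile, an amine or a carboxylic acid, would compare with fluoro and tert-butyl on either core. They also leave open whether the change behaves in the same way on any further core, and how much of the difference between the two cores can be assigned to any one part of them.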